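Replacing the sulfonamide on the piperidine ring of compound 3

The source may hold more compounds than are shown below. What is called first, only, known or untested is meant among the compounds shown, and "the series" means these compounds.

Compounds measured so far:
compound 1 `CC(C)=CCCN(C)C1CCN(CCCc2c[nH]c3ccc(-n4cnnc4)cc23)CC1`: 2.6 nM
compound 2 `c1cncc(CNC2CCN(CCCc3c[nH]c4ccc(-n5cnnc5)cc34)CC2)c1`: 35 nM
compound 3 `CN(C1CCN(CCCc2c[nH]c3ccc(-n4cnnc4)cc23)CC1)S(=O)(=O)c1ccccc1`: 1.5 nM

In an assay on CHO cells for displacement of a labelled ligand from 5-hydroxytryptamine receptor 1D (Homo sapiens) (on this read-out higher numbers stand for weaker inhibition and lower numbers for stronger inhibition), compound 3 gives the lowest number of the three; compound 1 lies within the scatter of it, while compound 2 lies well beyond it, as a 23-fold lower number from compound 2 to compound 3 (1.37 log units; beyond the scatter) shows. Compound 4 `c1ccc2c(c1)CCC2NCC1CCN(CCCc2c[nH]c3ccc(-n4cnnc4)cc23)CC1` is not yet measured. It differs from compound 3 by ((2,3-dihydro-1H-inden-1-yl)amino)methyl in place of methyl(phenylsulfonyl)amino on a saturated ring carbon. The two steps that touch the same place are a 13-fold higher number from compound 1 to compound 2 (1.13 log units; beyond the scatter) and a 23-fold lower number from compound 2 to compound 3 (1.37 log units; beyond the scatter); both were large, and compound 2, the one secondary amine among the three, gave the highest number. A secondary amine enters again here, so a higher number is expected, though with an uncertain size: the step of an 8.0-fold higher number from compound 3 to compound 4 (0.90 log units; beyond the scatter) is the estimate. Compound 4 is expected near 12 nM, within 3 nM to 50 nM.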

Compound 4, half-maximal inhibitory concentration: 1.1 nM
For compound 4 the middle estimate is 11-fold (1.04 log units) above the measured one, and the stated range ends above it.
By their numbers in this assay, from the lowest: compounds 4, 3 and 1 (each within the scatter of the next, the first and the last beyond it); then compound 2.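

In this assay, the secondary amine of compound 4 serves at this saturated ring carbon as well as the sulfonamide of compound 3 (a 1.4-fold lower number from compound 3 to compound 4 (0.13 log units; within the scatter)). A secondary amine therefore does not by itself bring the high number of compound 2 (a 32-fold lower number from compound 2 to compound 4 (1.50 log units; beyond the scatter)). Compound 4 also edges past the tertiary amine of compound 1 (a 2.4-fold lower number from compound 1 to compound 4 (0.37 log units; beyond the scatter)).

On these data alone, whether an N-methyl group on that amine, or a carboxylic acid on the 2,3-dihydro-1H-inden-1-yl ring, would keep the number this low remains open. No evidence here explains the gap between the two secondary amines.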